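The source may hold more compounds than are shown below. What is called first, only, known or untested is meant among the compounds shown, and "the series" means these compounds.

Measured so far in an assay on HEK293 cells for inhibition of Voltage-dependent T-type calcium channel subunit alpha-1G (Homo sapiens), read by fluorescence, tested at 10 uM; on this read-out lower numbers stand for less inhibition and higher numbers for more inhibition at the one concentration tested (going by the name of the read-out):

compound 1, `CCCc1nc(-c2ccccc2)c(CNCCCN2CCN(c3cccc(Cl)c3)CC2)o1`, gives 65.9%
compound 2, `CCCc1nc(-c2ccccc2)c(CNCCCN2CCN(c3ccccc3OC)CC2)o1`, gives 41%
compound 3, `CCCc1nc(-c2ccccc2)c(CNCCCN2CCN(c3cccc(C)c3)CC2)o1`, gives 47.8%

Compound 3 stands second highest of the three numbers. Its nearest neighbour is compound 2, and the gap between them, a number 6.8 percentage points higher from compound 2 to compound 3 (within the scatter), lies within the scatter of repeated measurements. Its furthest neighbour is compound 1, and the step of a number 18.1 percentage points lower from compound 1 to compound 3 (beyond the scatter) lies beyond the scatter.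

The next compound, compound 4, `CCCc1nc(-c2ccccc2)c(CNCCCN2CCN(c3ccccc3C)CC2)o1`, has the same atoms as compound 3 joined differently: 2-methylphenyl in place of 3-methylphenyl on an amine nitrogen in a ring.

For the measured compounds named here, no measured pair carries exactly this change. Going by the values given here, the steps that bear on it are those altering the group on the ring nitrogen: a number 24.9 percentage points lower from compound 1 to compound 2 (beyond the scatter) and a number 6.8 percentage points higher from compound 2 to compound 3 (within the scatter). Among the compounds with values here, the first shows that a change of this group can shift the read-out modestly; the second shows that a different exchange of the same group stays within the scatter. Compound 2, which also bears a group described as 2-substituted, gave 41%, a value somewhat lower than that of compound 3. A small downward step or none beyond the scatter in this assay is therefore expected, as a number 5.8 percentage points lower from compound 3 to compound 4 (within the scatter). Compound 4 is expected to give about 42%, within a range from 25% to 60%.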

Compound 4, a percentage reported as inhibition, at one concentration (the size of the read-out at that concentration, not a potency): 54.5%
The estimate for compound 4 lay 12.5 percentage points below the measured number; measured number inside the range.
By their numbers in this assay, from the lowest: compounds 2, 3 and 4 (each within the scatter of the next, the first and the last beyond it); then compound 1.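

Moving the methyl group on the phenyl ring gives a number 6.7 percentage points higher from compound 3 to compound 4 (within the scatter) in this assay, so the two methylphenyl isomers cannot be told apart in this read-out. The exchange of methoxy for methyl on the same aromatic carbon gives a clearer result, a number 13.5 percentage points higher from compound 2 to compound 4 (beyond the scatter), which shows that with the group's place on the phenyl ring held fixed, the identity of that group can still move the number beyond the scatter. The 3-chlorophenyl compound also keeps a modest edge over the new compound, with a number 11.4 percentage points lower from compound 1 to compound 4 (beyond the scatter), so among these four compounds the choice of group on the phenyl ring counts for more than the methyl group's place on it, while compound 2 and compound 3 stay within the scatter of each other.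

Nothing given here explains why any of these steps takes the size it does. As far as these compounds go, it remains open whether a 2-chlorophenyl group would match the number of the 3-chlorophenyl compound, and whether a 3-methoxyphenyl group would stay close to the 2-methoxyphenyl compound, as the two methylphenyl isomers stay close to each other.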